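This account rests on a few compounds, and the source may have more. Where it says the series, first, only, none or still open, it means among the compounds named here.

The measured compounds and their values:

Compound 1, `Fc1ccc(Cc2ccc3c(NCCCNCc4ccco4)ccnc3c2)c(Cl)c1`, 9.47
Compound 2, `COc1ccc(F)cc1CNCCCNc1ccnc2cc(Cc3ccc(F)cc3)ccc12`, 9.47
Compound 3, `COc1ccc(F)cc1CNCCCNc1ccnc2cc(Cc3ccc(F)cc3Cl)ccc12`, 9.47

The read-out here is a physicochemical assay for acid dissociation. Compound 1 stands level with compounds 2 and 3 on this read-out: the difference from compound 1 to compound 3 is no change at the digits printed from compound 1 to compound 3 (within the scatter), and from compound 2 to compound 3 it is no change at the digits printed from compound 2 to compound 3 (within the scatter). Neither change moved the number, so all three compounds sit together.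

The new compound is compound 4, `c1coc(CNCCCNc2ccnc3cc(C4CCCCC4)ccc23)c1`. Compared with compound 1, the change is cyclohexyl in place of 2-chloro-4-fluorobenzyl on an aromatic carbon. The step from compound 1 to compound 3 replaced the group on the chain carbon next to the amine and left the read-out untouched; the step from compound 2 to compound 3 altered the very group that now leaves, with a chloro in place of a hydrogen, and again nothing moved. Both steps, taken together, suggest that changes at these outlying positions do not reach the measured proton, so for compound 4 no step beyond the scatter is expected in this assay.

Compound 4 is therefore expected to give 9.47, with a likely range from 9.15 to 9.8, which means an expected step of no change at the digits printed from compound 1 to compound 4 (within the scatter) from compound 1.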

Compound 4, acid dissociation constant: 9.47
Compound 4: middle estimate and measured number agree at the digits printed, and the stated range covers the measured number.
By their numbers in this assay, from the lowest: compounds 1, 2, 3 and 4 (each within the scatter of the next).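

In this assay, putting cyclohexyl in place of 2-chloro-4-fluorobenzyl on this aromatic carbon gives no change at the digits printed from compound 1 to compound 4 (within the scatter). The earlier step at this place only added a chloro in place of hydrogen on a group that otherwise stayed the same, whereas here the whole group is exchanged: 9 heavy atoms with a six-membered aromatic ring, a fluorine and a chlorine give way to 6 heavy atoms with a six-membered non-aromatic ring of carbon only. Among the compounds shown, then, the read-out stays the same even when the ring type, the size and the halogens at this place all change at once, although the leaving and entering groups share 0 hydrogen-bond donors, 0 hydrogen-bond acceptors and no net charge.

As far as these compounds go, it remains open whether the number would hold with an amine or a carboxylic acid on this aromatic carbon, since either would differ from both of these groups in a way that cyclohexyl does not. Nothing measured here speaks to why the number stays level across this exchange.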